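An aromatic swap on the shared core

The source may hold more compounds than are shown below. What is called first, only, known or untested is meant among the compounds shown, and "the series" means these compounds.

In an ADME assay (liver) for metabolic stability, with Liver microsome (Homo sapiens) as the target, using microsomes and NADPH, with a stated time of 30 min, tested at 1 uM (a higher number here means faster removal of the compound, a lower number slower removal), compound 1 `Nc1ccc(S(=O)(=O)N2CCN(c3ncc(C(O)(C(F)(F)F)C(F)(F)F)cc3C#CCO)CC2)cn1` gives < 14 mL.min-1.g-1, which is a limit of the assay and not a number. Going by the values given here, compound 2 `Cc1ccc(-c2cc(C(O)(C(F)(F)F)C(F)(F)F)cnc2N2CCN(S(=O)(=O)c3ccc(N)nc3)CC2)cn1` gives 43 mL.min-1.g-1, the only true number so far. Among the compounds with values here, the single measured step, an at least 3.0-fold higher number from compound 1 to compound 2 (0.48 log units; beyond the scatter), put 6-methylpyridin-3-yl in place of 3-hydroxyprop-1-yn-1-yl on an aromatic carbon, and it lies beyond the scatter. Compound 3 `Nc1ccc(S(=O)(=O)N2CCN(c3ncc(C(O)(C(F)(F)F)C(F)(F)F)cc3-c3ccc4scnc4c3)CC2)cn1` changes that same carbon again, with 1,3-benzothiazol-5-yl in place of 6-methylpyridin-3-yl (1,3-benzothiazol-5-yl in place of 6-methylpyridin-3-yl on an aromatic carbon). Within the data shown here, the measured step replaced a chain with an aromatic ring, whereas this one replaces one aromatic group with another, and no measured pair shows such a swap. The value of compound 2 at 43 mL.min-1.g-1 is therefore the best starting point. The expected change, a 1.2-fold higher number from compound 2 to compound 3 (0.07 log units; within the scatter), stays within the scatter. Compound 3 is estimated at 50 mL.min-1.g-1, with an expected range of 22 mL.min-1.g-1 to 110 mL.min-1.g-1.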

Compound 3, intrinsic clearance in microsomes: 39 mL.min-1.g-1
For compound 3 the middle estimate is 1.3-fold (0.11 log units) above the measured one; the measured number falls inside the stated range.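

Putting 1,3-benzothiazol-5-yl on this aromatic carbon in place of 6-methylpyridin-3-yl gives a 1.1-fold lower number from compound 2 to compound 3 (0.04 log units; within the scatter) in this assay, so these two aromatic groups cannot be told apart here, even though one adds a five-membered ring and a sulfur atom. Replacing the 3-hydroxyprop-1-yn-1-yl chain with the same new group gives an at least 2.7-fold higher number from compound 1 to compound 3 (0.44 log units; beyond the scatter), so the earlier rise now appears with a second aromatic group and does not rest on 6-methylpyridin-3-yl alone. The value of compound 1 behind this step is a limit and not a number: the limit of < 14 mL.min-1.g-1 in this assay, at which 1 of the 3 values shown sits.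

The compounds shown do not reveal whether the slower removal of compound 1 goes with the hydroxyl group or with the triple bond of its chain. On these data alone, how a small group on this carbon, such as a methyl group or an amine, would behave also stays open.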